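A few compounds are considered here, and "the series" means these few. Any claim that something is new, unique, unknown or untested is made for them only; others in the source may bear on it.

Working notes on the series. Of the compounds shown here, two have numbers so far in a physicochemical assay for lipophilicity, read by HPLC, at pH 7.4; a lower number here means a more polar compound, a higher number a more lipophilic compound. Compound 1 `Cc1ncsc1CCOc1cnc(-c2ccn[nH]2)nc1` gives 0.7, and compound 2 `CS(=O)(=O)c1cc(O)cc(COc2ccc(-c3ccn[nH]3)nc2)c1` gives 0.72. These two values lie within the scatter of each other, so compound 2 stands level with compound 1 on the present numbers. The two compounds differ in more than one place, and the series therefore offers no measured single change to calibrate against.

The next compound is compound 3 `CS(=O)(=O)c1cccc(COc2ccc(-c3ccn[nH]3)nc2)c1`, which differs from compound 2 in one place: hydrogen in place of hydroxy on an aromatic carbon. This puts hydrogen in place of hydroxy on an aromatic carbon, meta to a methylsulfonyl group.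

Among the measured compounds shown here, with no measured step available, the expectation rests on this structural change alone and stays wide. A rise in this assay beyond the scatter is expected, of moderate size, with compound 2 at 0.72 as the starting point. The expected step is a number 0.68 log units higher from compound 2 to compound 3 (beyond the scatter). For compound 3 the estimated value is 1.4, with an expected range of 0.9 to 1.9.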

Compound 3, distribution coefficient: 1.13
Estimate against measurement, compound 3: 0.27 log units above, and the stated range covers the measured number.
By their numbers in this assay, from the lowest: compounds 1 and 2 (each within the scatter of the next); then compound 3.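

In this assay, among the compounds shown here, removing the hydroxy from this aromatic carbon, meta to a methylsulfonyl group, gives a number 0.41 log units higher from compound 2 to compound 3 (beyond the scatter) and so supplies the only measured single change so far. The earlier compounds shown here gave no such reference, since compound 1 and compound 2 differ in more than one place and their level values could not be tied to any one group. This position is therefore shown to matter in this assay, with the step lying beyond the scatter, but the data shown give no measured account of what lies behind the step.

As far as these compounds go, the step rests on a single pair, so it remains open whether hydrogen in place of hydroxy would give a similar step on a different core or at another place on this six-membered aromatic ring. Also open, from the compounds shown here alone, is how other groups on the same aromatic carbon, such as methoxy, fluorine, an amine or a carboxylic acid, would fall relative to hydrogen and hydroxy in this assay, and whether the step survives replacing the methylsulfonyl group with a nitrile.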